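Ring-nitrogen methyl on the piperazine of compound 2

A few compounds are considered here, and "the series" means these few. Any claim that something is new, unique, unknown or untested is made for them only; others in the source may bear on it.

Three compounds of this series carry a number in a functional assay on CCRF-CEM cells for antagonist activity at C-X-C chemokine receptor type 4 (Homo sapiens), read by calcium flux, with stated times of 25 min and 90 s; on this read-out higher numbers stand for weaker inhibition and lower numbers for stronger inhibition. Compound 1 `CCCN(C[C@H]1Cc2c(cccc2N2CCNCC2)CN1)[C@H]1CCCc2cccnc21` gives 32.2 nM. Compound 2 `C[C@@H]1CN(c2cccc3c2C[C@H](CN(C)[C@H]2CCCc4cccnc42)NC3)C[C@H](C)N1` gives 61 nM. Compound 3 `CN1CCN(c2cccc3c2C[C@H](CN(C)[C@H]2CCCc4cccnc42)N(C)C3)CC1` gives 171 nM. On these numbers compound 2 stands second highest of the three: compound 1 lies within the scatter of it, while compound 3 gives a higher number by a step beyond the scatter. Compound 3 differs from compound 2 in more than one place, so no single change among the measured compounds is isolated.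

Compound 4 `C[C@@H]1CN(c2cccc3c2C[C@H](CN(C)[C@H]2CCCc4cccnc42)NC3)C[C@H](C)N1C` is not yet measured. It differs from compound 2 by methyl in place of hydrogen on an amine nitrogen in a ring, read one bond further out as 3,5-dimethylpiperazin-1-yl to 3,4,5-trimethylpiperazin-1-yl. Within the data shown here, no measured pair shows this change on its own; the closest guide is compound 3, whose methyl-bearing piperazine ring nitrogen comes together with a methyl on the core and a higher number.

For compound 4 a small step of a 1.3-fold higher number from compound 2 to compound 4 (0.12 log units; within the scatter) toward a higher number is expected, likely within the scatter. The estimate for compound 4 in this assay is 80 nM, with a range from 35 nM to 190 nM.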

Compound 4, half-maximal inhibitory concentration: 14.1 nM
Compound 4: the middle estimate sits 5.7-fold (0.75 log units) above what was measured; measured number below the stated range.
By their numbers in this assay, from the lowest: compound 4; then compounds 1 and 2 (each within the scatter of the next); then compound 3.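

In this assay the ring nitrogen of the 3,5-dimethylpiperazin-1-yl group accepts a methyl, and the change to 3,4,5-trimethylpiperazin-1-yl gives a 4.3-fold lower number from compound 2 to compound 4 (0.64 log units; beyond the scatter) as the first single change isolated in this series, with the step lying beyond the scatter. The hydrogen on this amine nitrogen, next to two ring atoms that each bear a methyl group, is therefore not needed for inhibition in this pair, and replacing it with methyl strengthens the read-out. The higher number of compound 3 cannot be read as a cost of a ring-nitrogen methyl, as that compound differs in more than one place, and nothing measured here explains the direction of the step.

The compounds shown leave open whether the gain depends on the two ring methyl groups, since no pair shows the same change on a piperazine without them. They also leave open how much room this nitrogen offers beyond methyl, as an ethyl, an isopropyl or an acetyl group there would test whether the trend continues or ends with the smallest substituent.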